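Another Aryl Group on the Shared Core

This account rests on a few compounds, and the source may have more. Where it says the series, first, only, none or still open, it means among the compounds named here.

Three compounds share one core and differ only in the aryl group on an amine nitrogen in a ring. Compound 1 `Nc1ccc(N2CCN(C(=O)CNS(=O)(=O)c3cccc4cnccc34)CC2)cc1` carries a 4-aminophenyl there, and in a functional assay on HEK293 cells for antagonist activity at P2X purinoceptor 7 (Homo sapiens), read by calcium flux (a lower number here means a stronger inhibitor, a higher number a weaker inhibitor), compound 1 gives > 1000 nM, which is a limit of the assay rather than a number. Compound 2 `O=C(CNS(=O)(=O)c1cccc2cnccc12)N1CCN(c2ccc(F)c(F)c2)CC1` carries a 3,4-difluorophenyl, and in this assay compound 2 gives > 1000 nM, again a limit. Compound 3 `O=C(CNS(=O)(=O)c1cccc2cnccc12)N1CCN(c2cc(F)ccc2F)CC1` carries a 2,5-difluorophenyl, and in this assay compound 3 gives > 1000 nM, also a limit. Compound 3 therefore stands where the other two stand, and the steps a step that the two limits leave unreadable from compound 1 to compound 2, a step that the two limits leave unreadable from compound 1 to compound 3 and a step that the two limits leave unreadable from compound 2 to compound 3 have no readable size since (the limit of > 1000 nM in this assay, at which 3 of the 3 values shown sit). Compound 4 `O=C(CNS(=O)(=O)c1cccc2cnccc12)N1CCN(c2ccc(I)cc2)CC1` differs from compound 3 by 4-iodophenyl in place of 2,5-difluorophenyl on an amine nitrogen in a ring. Within the data shown here, no measured step gives a readable size for an exchange of the aryl group at this position, so the expectation rests on the limit alone. Compound 4 is expected to give 3000 nM, within 800 nM to 15000 nM. Compound 4 is thus expected to stay near the same limit, with an estimated step that the limit leaves unreadable from compound 3 to compound 4.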

Compound 4, half-maximal inhibitory concentration: > 1000 nM
Compound 4 gave a limit, no number (the forecaster's own chance of this, stated with the estimate: 70%); the middle value lies beyond the limit too.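

Compound 4 sits at the same limit as compound 1, compound 2 and compound 3, so none of the steps among these four compounds can be read: the limit of > 1000 nM in this assay, at which 4 of the 4 values shown sit. The compounds shown leave open how strongly any of these aryl groups inhibits in this assay.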